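A few compounds are considered here, and "the series" means these few. Any claim that something is new, unique, unknown or untested is made for them only; others in the source may bear on it.

Working notes on the series. In a functional assay on MDA-MB-435 cells (Homo sapiens) for inhibition (on this read-out lower numbers stand for stronger inhibition and higher numbers for weaker inhibition), compound 1 `O=C(/C=C/c1ccc(F)c(Cl)c1)c1ccc(B(O)O)cc1` gives 16000 nM, and compound 2 `O=C(O)COc1ccc(C(=O)/C=C/c2ccc(Cl)c(Cl)c2)cc1` gives 9000 nM; compound 2 stands lowest of the two numbers, but its nearest neighbour is compound 1, within the scatter, so no order between them can be read. Compound 3 `O=C(/C=C/c1ccc(Cl)c(Cl)c1)c1ccc(B(O)O)cc1` differs from compound 2 by a group of 3 heavy atoms (1 boron, 2 oxygen; no ring) in place of a group of 5 heavy atoms (2 carbon, 3 oxygen; no ring), on an aromatic carbon, on an aromatic carbon para to a large group. For the measured compounds named here, no step between measured compounds is available, so the change from compound 2 to compound 3 is expected to be small and upward, if anything, not beyond the scatter: a 1.3-fold higher number from compound 2 to compound 3 (0.12 log units; within the scatter). For compound 3 the estimate in this assay is 12000 nM, with a range from 5000 nM to 30000 nM.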

Compound 3, half-maximal inhibitory concentration: 3500 nM
The estimate for compound 3 lay 3.4-fold (0.54 log units) above the measured number; measured number below the stated range.
By their numbers in this assay, from the lowest: compound 3; then compounds 2 and 1 (each within the scatter of the next).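

In this assay, the group of 3 heavy atoms (1 boron, 2 oxygen) in place of carboxymethoxy, on the aromatic carbon para to a large group, gives a 2.6-fold lower number from compound 2 to compound 3 (0.41 log units; beyond the scatter) and shows that the number responds to a change at this position. With that group held, chloro in place of fluoro on an aromatic carbon gives a 4.6-fold lower number from compound 1 to compound 3 (0.66 log units; beyond the scatter) and shows that a second place on the shared core also moves the number. No available measurement bears on the cause of either step.

Going by these compounds, whether an amine or a longer chain at the same position would give a lower or higher number remains open. So does whether the chloro step would hold with carboxymethoxy in place.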